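The compounds below may be only part of what the source reports. "The series", "measured", "known", "first", "only" and "open" are said of these compounds alone.

Measured compounds, toxicity read as dose for half-maximal effect:

compound 1 `C#CCNC(=O)/C(C)=C(\C)c1ccc(Br)cc1` — 180 mg/kg
compound 2 `C=CCNC(=O)/C(C)=C(/C)c1ccccc1` — 550 mg/kg
compound 3 `C#CCNC(=O)/C(C)=C(\C)c1ccc(OC)cc1` — 150 mg/kg

In a toxicity assay on the whole organism (strain Icem-CET (SPF Caw)) for cytotoxicity, with Mus musculus as the target (a lower number here means that less compound is needed, a higher number that more compound is needed for the effect), compound 3 gives the lowest number of the three. The nearest number is that of compound 1, and the step of a 1.2-fold lower number from compound 1 to compound 3 (0.08 log units; within the scatter) lies within the scatter, so the two are not told apart. Compound 2 gives the highest number, and the gap from compound 3 to compound 2 is beyond the scatter; as compound 2 differs from compound 3 in two places at once, it carries no single-change lesson.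

The next compound is compound 4 `C#CCNC(=O)/C(C)=C(\C)c1ccc(Cl)cc1`. The change from compound 3 is chloro in place of methoxy on an aromatic carbon. Going by the values given here, the only measured step that bears on it is the reverse of this kind of exchange, methoxy for a halogen at the same place, with compound 1 and compound 3 at its ends: within the scatter. Chloro now takes the place that bromo held in compound 1, and nothing among the three measured compounds separates one halogen from another here. No step beyond the scatter is therefore expected in this assay; the estimated step is a 1.1-fold higher number from compound 3 to compound 4 (0.05 log units; within the scatter). For compound 4 the expected value in this assay is 170 mg/kg, with a range from 90 mg/kg to 330 mg/kg.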

Compound 4, dose for half-maximal effect: 60 mg/kg
Beside the measured number, compound 4's estimate is 2.8-fold (0.45 log units) above it; measured number outside the range, below it.
By their numbers in this assay, from the lowest: compound 4; then compounds 3 and 1 (each within the scatter of the next); then compound 2.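

In this assay, the group on this aromatic carbon, para to a large group, now makes a difference: a 2.5-fold lower number from compound 3 to compound 4 (0.40 log units; beyond the scatter), and a 3.0-fold lower number from compound 1 to compound 4 (0.48 log units; beyond the scatter). The earlier exchange of bromo for methoxy had stayed within the scatter, so the flat picture it suggested does not extend to chloro, which stands apart from both groups while compound 1 and compound 3 remain untold apart. The two halogens are thus not interchangeable at this place, although only one halogen pair is shown, and nothing at hand gives a measured reason for the separation of chloro from bromo and methoxy.

Whether the low number of compound 4 is particular to chloro stays open, since fluoro, trifluoromethyl or an amine on the same aromatic carbon do not appear among the compounds shown. Going by these compounds alone, also open is whether the chloro result holds with another chain on the amide nitrogen, as compound 2, the only compound with a different chain, differs from the others in more than one place.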